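Replacing tert-butyl with cyclopropyl on the shared core

This account rests on a few compounds, and the source may have more. Where it says the series, first, only, none or still open, it means among the compounds named here.

In a functional assay (aorta) with Rattus norvegicus as the target (on this read-out lower numbers stand for stronger inhibition and higher numbers for weaker inhibition), compound 3 `CCCCN(CCCC)CCCOc1ccc(S(=O)(=O)c2c(C(C)(C)C)cn3ccccc23)cc1` stands lowest of the three measured compounds at 51.9 nM. Compound 2 `CC(C)(C)NCCCOc1ccc(S(=O)(=O)c2c(C(C)(C)C)cn3ccccc23)cc1` gives 443 nM and compound 1 `CCN(CC)CCCOc1ccc(S(=O)(=O)c2c(C)cn3ccccc23)cc1` gives 3390 nM, both beyond the scatter from compound 3. The next compound, compound 4 `CCCCN(CCCC)CCCOc1ccc(S(=O)(=O)c2c(C3CC3)cn3ccccc23)cc1`, keeps the dibutylamino group of compound 3 and carries cyclopropyl in place of tert-butyl on an aromatic carbon.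

Among the compounds with values here, the only measured step that changes one place is an 8.5-fold lower number from compound 2 to compound 3 (0.93 log units; beyond the scatter), and it concerns the amino group on the chain, not this aromatic carbon. Compound 1 carries a methyl group on that carbon but also differs from compound 3 in its amino group, so its value cannot isolate the contribution of the carbon's substituent. Within the data shown here, no measured step therefore sizes this exchange or gives it a direction. No step beyond the scatter is expected in this assay, although the uncertainty is wide. The estimated step is a 1.2-fold lower number from compound 3 to compound 4 (0.06 log units; within the scatter). For compound 4 the expected value is 45 nM, with an estimated range of 12 nM to 170 nM.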

Compound 4, half-maximal inhibitory concentration: 10.9 nM
For compound 4 the middle estimate is 4.1-fold (0.62 log units) above the measured one, outside the stated range (below it).
By their numbers in this assay, from the lowest: compound 4; then compound 3; then compound 2; then compound 1.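

In this assay the aromatic carbon of the five-membered ring now has a sized exchange of its own: cyclopropyl in place of tert-butyl gives a 4.8-fold lower number from compound 3 to compound 4 (0.68 log units; beyond the scatter), with the dibutylamino group held the same. Earlier, the only single-place step was an 8.5-fold lower number from compound 2 to compound 3 (0.93 log units; beyond the scatter), on the amino group of the chain, so both this aromatic carbon and that amino group are now shown to move the read-out beyond the scatter, and compound 4 at 10.9 nM has the lowest number of the four compounds shown. The data hold no separate measurement that accounts for the step at this carbon.

As far as these compounds go, compound 1 carries methyl on this carbon but also differs in its amino group, so the position of a methyl group alongside dibutylamino stays open, as does the outcome with isopropyl or cyclobutyl on the same carbon. Also open, from the compounds shown here alone, is whether cyclopropyl in place of tert-butyl gives a step of similar direction when the chain ends in (tert-butyl)amino, as in compound 2, or in a different amine such as piperidine.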